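Swapping the benzyl substituent in a bromoindole oxime ether

This account rests on a few compounds, and the source may have more. Where it says the series, first, only, none or still open, it means among the compounds named here.

In a functional assay on MGC-803 cells (Homo sapiens) for cytotoxicity, read by MTT assay, with a stated time of 2 days (a lower number here means a stronger inhibitor, a higher number a weaker inhibitor), compound 1 `Cc1ccc(CO/N=C2/C(c3c[nH]c4ccc(Br)cc34)=Nc3ccc(Br)cc32)cc1` gives 31200 nM, and compound 2 `FC(F)(F)c1ccc(CO/N=C2/C(c3c[nH]c4ccc(Br)cc34)=Nc3ccc(Br)cc32)cc1` gives 11100 nM; the step of a 2.8-fold lower number from compound 1 to compound 2 (0.45 log units; beyond the scatter) makes compound 2 the lower of the two numbers. Compound 3 `Clc1cccc(CO/N=C2/C(c3c[nH]c4ccc(Br)cc34)=Nc3ccc(Br)cc32)c1` differs from compound 2 by 3-chlorophenyl in place of 4-(trifluoromethyl)phenyl on a saturated chain carbon bound to an oxygen on an unsaturated carbon. For the measured compounds named here, only the step from compound 1 to compound 2 bears on this change, and it was modest, so in this assay the expected step of a 1.4-fold higher number from compound 2 to compound 3 (0.13 log units; within the scatter) is small, likely within the scatter. Compound 3 is estimated at 15000 nM, in a range from 6000 nM to 40000 nM.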

Compound 3, half-maximal inhibitory concentration: 7600 nM
Estimate against measurement, compound 3: 2.0-fold (0.30 log units) above, within the range that was stated.
By their numbers in this assay, from the lowest: compounds 3 and 2 (each within the scatter of the next); then compound 1.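

A chlorine at the 3-position of the benzyl ring does about as well as a trifluoromethyl at the 4-position: in this assay the change shows a 1.5-fold lower number from compound 2 to compound 3 (0.16 log units; within the scatter). Against the 4-methylphenyl group, the same 3-chlorophenyl group shows a 4.1-fold lower number from compound 1 to compound 3 (0.61 log units; beyond the scatter), so the methyl compound is not matched by either replacement tried. Nothing available explains these differences.

The compounds shown do not separate the effect of changing the substituent from that of moving it around the ring. On these data alone, how an amine or a carboxylic acid on this ring would behave also remains open.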